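This account rests on a few compounds, and the source may have more. Where it says the series, first, only, none or still open, it means among the compounds named here.

Measured so far:
compound 1 `COc1ccc(C2CC(=O)C=CO2)cc1` — a functional assay on NCI/ADR cells (Homo sapiens) for inhibition, read by sulforhodamine B assay, with a stated time of 48 h; on this read-out lower numbers stand for stronger inhibition of growth and higher numbers for weaker inhibition of growth: 420 uM
compound 2 `COc1ccc(C2CC(=O)C(Br)=CO2)cc1` — this assay : 52.9 uM

For the measured compounds named here, compound 2 stands at the lower of the two numbers; the one measured step, a 7.9-fold lower number from compound 1 to compound 2 (0.90 log units; beyond the scatter), separates it from compound 1. Compound 3 `COc1ccc(C2CC(=O)C(I)=CO2)cc1` differs from compound 2 by iodo in place of bromo on a double-bonded ring carbon. Only a 7.9-fold lower number from compound 1 to compound 2 (0.90 log units; beyond the scatter) bears on this change, and it concerns bromo against hydrogen, not iodo against bromo, so no step beyond the scatter is expected in this assay, at most a slight lowering. Compound 3 is estimated at 40 uM, range 15 uM to 120 uM, an expected step of a 1.3-fold lower number from compound 2 to compound 3 (0.12 log units; within the scatter).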

Compound 3, concentration for growth inhibition (reported as GI): 39.7 uM
Compound 3: middle estimate off by 1.0-fold (0.00 log units), on the high side; the range from low to high includes it.
By their numbers in this assay, from the lowest: compounds 3 and 2 (each within the scatter of the next); then compound 1.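

In this assay, iodo in place of bromo gives a 1.3-fold lower number from compound 2 to compound 3 (0.12 log units; within the scatter), so on this double-bonded ring carbon the two halogens are not told apart. Iodo in place of hydrogen gives an 11-fold lower number from compound 1 to compound 3 (1.02 log units; beyond the scatter) as its step, which shows that the drop in the number seen with bromo is not limited to that one halogen. Nothing available gives a reason for this result.

Open, going by these compounds, is whether a non-halogen group on this carbon, such as a nitrile, a methyl or an amine, would give a similar step. Also open, on these data alone, is whether chloro or fluoro would match bromo and iodo.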